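Thienopyrimidine stilbenes: amine to benzyl ether switch

The compounds below may be only part of what the source reports. "The series", "measured", "known", "first", "only" and "open" are said of these compounds alone.

Measured so far:
compound 1 `COc1cc(/C=C/c2nc(Nc3ccc(C(C)C)cc3)c3sccc3n2)cc(OC)c1OC` — 370000 nM
compound 2 `COc1cc(/C=C/c2nc(Nc3ccc(C(F)(F)F)cc3)c3sccc3n2)cc(OC)c1OC` — 436000 nM

Both compounds carry the same trimethoxystyryl core; in a functional assay on L02 cells (Homo sapiens) for inhibition, read by Griess assay, with stated times of 1 h and 24 h (on this read-out higher numbers stand for weaker inhibition and lower numbers for stronger inhibition), compound 1 gives 370000 nM and compound 2 gives 436000 nM. For the measured compounds named here, compound 2 stands at the highest of the two numbers, but its only neighbour is compound 1, and the single measured step, a 1.2-fold higher number from compound 1 to compound 2 (0.07 log units; within the scatter), lies within the scatter, so the two values cannot be told apart.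

Compound 3 `COc1cc(/C=C/c2nc(OCc3ccccc3)c3sccc3n2)cc(OC)c1OC` is unmeasured. It differs from compound 2 by benzyloxy in place of (4-(trifluoromethyl)phenyl)amino on an aromatic carbon. Going by the values given here, no measured step bears on this change: the one step available concerns trifluoromethyl in place of isopropyl on the distal ring, not the exchange of the whole (4-(trifluoromethyl)phenyl)amino group for benzyloxy. Among the compounds with values here, with no comparable pair to lean on, the expectation for compound 3 in this assay is simply a number close to that of compound 2, with a wide range to reflect the lack of precedent. For compound 3 the estimated step is a 1.0-fold higher number from compound 2 to compound 3 (0.01 log units; within the scatter). Compound 3 is therefore expected to give about 450000 nM, likely between 150000 nM and 1500000 nM.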

Compound 3, half-maximal inhibitory concentration: > 1000000 nM
Compound 3 gave a limit, no number; the forecaster's own chance of this, stated with the estimate: 25%; middle value at least 2.2-fold (0.34 log units) from the limit.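

In this assay compound 3 gives > 1000000 nM, a limit of the assay and not a number. Benzyloxy in place of (4-(trifluoromethyl)phenyl)amino on this aromatic carbon gives an at least 2.2-fold higher number from compound 2 to compound 3 (0.36 log units; beyond the scatter), and benzyloxy in place of (4-isopropylphenyl)amino gives an at least 2.7-fold higher number from compound 1 to compound 3 (0.43 log units; beyond the scatter), so the group at this position shifts the read-out towards weaker inhibition by more than the scatter, whereas trifluoromethyl in place of isopropyl on the distal ring gave only a 1.2-fold higher number from compound 1 to compound 2 (0.07 log units; within the scatter). Only a lower bound on both new steps can be read, and compound 3 is the one compound at the edge of the range: the limit of > 1000000 nM in this assay, at which 1 of the 3 values shown sits.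

The change removes the amino link and the substituent on the aromatic ring in one exchange, so the compounds shown do not separate the two; a benzylamino or phenoxy group on this carbon would bear on that. On these data alone, whether a carboxylic acid or a morpholine on the distal ring would bring the number below those of compound 1 and compound 2 in this assay also stays open.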